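This account rests on a few compounds, and the source may have more. Where it says the series, first, only, none or still open, it means among the compounds named here.

Series values in a functional assay (Left cardiac atrium, Cavia porcellus), with a stated time of 30 min; a higher number here means that more compound is needed for the effect, a lower number that less compound is needed:
Compound 1 `CC1=CSC(O)(c2ccccc2)c2noc(=O)n21`: 230 nM
Compound 2 `COc1cccc(C2(O)SC=C(C)n3c2noc3=O)c1`: 490 nM

Of these two numbers, the higher belongs to compound 2, at 490 nM. Among the measured compounds shown here, the only measured step, a 2.1-fold higher number from compound 1 to compound 2 (0.33 log units; beyond the scatter), is modest and lies beyond the scatter.

Compound 3 `COc1cccc(C2(OC(C)C)SC=C(C)n3c2noc3=O)c1` differs from compound 2 by isopropyl in place of hydrogen on an oxygen on a saturated carbon, which reads as hydroxy to isopropoxy. The measured step concerns methoxy in place of hydrogen on an aromatic carbon, so it bears only indirectly and gives a rough scale at most. For the measured compounds named here, no measured step covers a change on this oxygen, and the data fix no direction. A step clearly beyond the scatter in this assay is therefore not expected, though the uncertainty is wide.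

The expected change is a 1.2-fold higher number from compound 2 to compound 3 (0.09 log units; within the scatter).

For compound 3, the estimated value is 600 nM, with an expected range of 130 nM to 2500 nM.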

Compound 3, half-maximal effective concentration: 64 nM
For compound 3 the middle estimate is 9.4-fold (0.97 log units) above the measured one; the whole stated range lies above it.
By their numbers in this assay, from the lowest: compound 3; then compound 1; then compound 2.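

In this assay hydroxy to isopropoxy gives a 7.7-fold lower number from compound 2 to compound 3 (0.88 log units; beyond the scatter) and so less compound is needed with isopropyl on this oxygen; in this pair the hydrogen there is not required for the effect. The step runs opposite to a 2.1-fold higher number from compound 1 to compound 2 (0.33 log units; beyond the scatter) and is the larger of the two, so in the single case shown for each place, the change on the oxygen moves the number further than the change on the aromatic carbon. Nothing at hand explains this step.

As far as these compounds go, whether the lower number depends on isopropyl itself stays open: a methoxy or a longer chain on this oxygen would show how far it follows the size of the group. Also open, from the compounds shown here alone, is whether the same change carries over to the core of compound 1, which has hydrogen in place of the methoxy.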